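A few compounds are considered here, and "the series" means these few. Any claim that something is new, unique, unknown or untested is made for them only; others in the source may bear on it.

Measured so far:
compound 1 `Cc1c(C(=O)N/N=C\c2c(O)cccc2F)oc2cccc(O)c12`, 8050 nM in a functional assay on PC-3 cells (Homo sapiens) for inhibition; a higher number here means a weaker inhibitor, a lower number a stronger inhibitor
compound 2 `Cc1c(C(=O)N/N=C\c2cc(F)ccc2O)oc2cccc(O)c12`, 3170 nM
compound 3 `Cc1c(C(=O)N/N=C\c2cc(Cl)cc(Cl)c2O)oc2cccc(O)c12`, 9590 nM

Compound 1 stands second highest of the three numbers; compound 3 lies within the scatter of it, compound 2 well below. The change to compound 4 `Cc1c(C(=O)N/N=C\c2cc(Cl)ccc2O)oc2cccc(O)c12`: 5-chloro-2-hydroxyphenyl in place of 2-fluoro-6-hydroxyphenyl on a carbon with a double bond to nitrogen. Among the measured compounds shown here, the only step that bears on it is a 2.5-fold lower number from compound 1 to compound 2 (0.40 log units; beyond the scatter), which put a 5-fluoro-2-hydroxyphenyl in the same place. Compound 4 carries the chloro counterpart of that group; no single-site chloro-for-fluoro comparison exists here, and compound 3 gives a number within the scatter of compound 1. A modest lowering of about the earlier size is therefore expected, as a 2.3-fold lower number from compound 1 to compound 4 (0.36 log units; beyond the scatter). For compound 4 the estimate in this assay is 3500 nM, expected range 1500 nM to 8000 nM.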

Compound 4, half-maximal inhibitory concentration: 3120 nM
For compound 4 the middle estimate is 1.1-fold (0.05 log units) above the measured one; the range from low to high includes it.
By their numbers in this assay, from the lowest: compounds 4 and 2 (each within the scatter of the next); then compounds 1 and 3 (each within the scatter of the next).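

In this assay, the lower number seen with the 5-fluoro-2-hydroxyphenyl group also holds for 5-chloro-2-hydroxyphenyl (a 2.6-fold lower number from compound 1 to compound 4 (0.41 log units; beyond the scatter)). Chloro in place of fluoro on this aromatic carbon makes no difference beyond the scatter (a 1.0-fold lower number from compound 2 to compound 4 (0.01 log units; within the scatter)). Hydrogen in place of the further chloro does lower the number (a 3.1-fold lower number from compound 3 to compound 4 (0.49 log units; beyond the scatter)), so a single chloro on this ring differs from two.

No supporting data explain these differences. Going by these compounds, whether a methoxy group or an amine in place of the hydroxy group would preserve these numbers remains open.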